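The source may hold more compounds than are shown below. What is called first, only, known or untested is meant among the compounds shown, and "the series" means these compounds.

Working notes on the series. Going by the values given here, compound 2 `Cc1cc(C)cc(-n2nc(-c3ccc(C(F)(F)F)cc3O)nc2-c2ccccc2O)c1` gives 105% in a functional assay on PC-12 cells (Rattus norvegicus) for cytotoxicity, read by MTT assay, with stated times of 2 h and 24 h, tested at 10 uM (on this read-out lower numbers stand for a weaker effect and higher numbers for a stronger effect at the one concentration tested), and nominally holds the upper of the two numbers measured so far; the nearest is compound 1 `Oc1cc(C(F)(F)F)ccc1-c1nc(-c2ccccc2O)n(-c2cccc(C(F)(F)F)c2)n1`, which gives 99.9% in this assay, a gap within the usual scatter. Among the compounds with values here, the one measured step, a number 5.1 percentage points higher from compound 1 to compound 2 (within the scatter), concerns the group on the aromatic nitrogen, the same place that changes now. Compound 3 `Oc1cc(C(F)(F)F)ccc1-c1nc(-c2ccccc2O)n(-c2cc(F)cc(F)c2)n1` differs from compound 2 in this way: 3,5-difluorophenyl in place of 3,5-dimethylphenyl on an aromatic nitrogen. Within the data shown here, the single step bearing on the change at this place was within the scatter, and both measured compounds already sit at a near-complete effect in this assay, so no step beyond the scatter is expected in either direction for compound 3; the expected step is a number 5 percentage points lower from compound 2 to compound 3 (within the scatter). In this assay compound 3 is therefore estimated at 100%, with a range from 85% to 112%.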

Compound 3, a percentage reported as activity, at one concentration (the size of the read-out at that concentration, not a potency): 106%
Compound 3: the middle estimate sits 6 percentage points below what was measured; low and high end bracket the measured number.
By their numbers in this assay, from the lowest: compounds 1, 2 and 3 (each within the scatter of the next).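

With 3,5-difluorophenyl on the aromatic nitrogen, this assay gives a number 1 percentage points higher from compound 2 to compound 3 (within the scatter), and against the first aryl group it gives a number 6.1 percentage points higher from compound 1 to compound 3 (within the scatter). The read-out therefore does not separate 3-(trifluoromethyl)phenyl, 3,5-dimethylphenyl and 3,5-difluorophenyl at this place, so fluorine in place of methyl on this ring, like the earlier exchange, produces no step beyond the scatter. Nothing at hand bears on why these three compounds read alike.

All three groups shown are substituted phenyl rings without hydrogen-bond donors or acceptors, so it remains open whether the read-out stays the same with a basic amine, a carboxylic acid or a longer alkyl chain on the aromatic nitrogen. Also open, as far as these compounds go, is how the shared core's other groups contribute to this read-out.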